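A few compounds are considered here, and "the series" means these few. Any claim that something is new, unique, unknown or untested is made for them only; others in the source may bear on it.

Working notes on the series. In a functional assay on HCT-116 cells (Homo sapiens) for cytotoxicity (a higher number here means a weaker inhibitor, a lower number a stronger inhibitor), compound 1 `COc1cc(N2CCNCC2)ccc1Nc1nc(NC2CCCCC2)c2nc[nH]c2n1` gives 88 nM and compound 2 `COc1cc(N2CCN(C(=O)C3CCC(O)CC3)CC2)ccc1Nc1nc(NC2CCCCC2)c2nc[nH]c2n1` gives 15 nM. Compound 3 `COc1cc(N2CCC(CC(=O)N3CCOCC3)CC2)ccc1Nc1nc(NC2CCCCC2)c2nc[nH]c2n1`, at 36 nM, holds the middle of the three numbers, with gaps beyond the scatter on both sides.

Compound 4 `COc1cc(N2CCC(C(=O)N3CC(O)C3)CC2)ccc1Nc1nc(NC2CCCCC2)c2nc[nH]c2n1` has not yet been measured. It replaces ((morpholin-4-yl)carbonyl)methyl with (3-hydroxyazetidin-1-yl)carbonyl on a saturated ring carbon: (3-hydroxyazetidin-1-yl)carbonyl in place of ((morpholin-4-yl)carbonyl)methyl on a saturated ring carbon.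

Going by the values given here, only one measured step is available, a 5.9-fold lower number from compound 1 to compound 2 (0.77 log units; beyond the scatter). This modest step comes with (4-hydroxycyclohexyl)carbonyl in place of hydrogen on an amine nitrogen in a ring. It bears on the new change only indirectly, since it involves a different place and a different group. Among the compounds with values here, no measured pair isolates the exchange at the saturated ring carbon. Compound 2 and compound 3 both sit below compound 1, and neither goes against that small pattern, which suggests that compound 4 may also stay in this lower range. With so little direct evidence, no clear step is expected in this assay. The estimated change is a 1.2-fold lower number from compound 3 to compound 4 (0.08 log units; within the scatter), which is expected to stay within the scatter. Compound 4 is estimated at 30 nM, with an expected range of 12 nM to 75 nM.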

Compound 4, half-maximal inhibitory concentration: 50 nM
Beside the measured number, compound 4's estimate is 1.7-fold (0.22 log units) below it, within the range that was stated.
By their numbers in this assay, from the lowest: compound 2; then compounds 3, 4 and 1 (each within the scatter of the next, the first and the last beyond it).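

In this assay, the exchange of ((morpholin-4-yl)carbonyl)methyl for (3-hydroxyazetidin-1-yl)carbonyl on the saturated ring carbon gives a 1.4-fold higher number from compound 3 to compound 4 (0.14 log units; within the scatter), so this position now carries two different amide groups with no step beyond the scatter between them. The exchange changes several things at once: a six-membered ring gives way to a four-membered one, the methyl between the saturated ring carbon and the carbonyl is gone, and a hydrogen-bond donor enters. This pair shows no step beyond the scatter for these changes taken together. It cannot assign any part of the result to any one of them. No measured evidence bears on why the two groups read alike.

The compounds shown leave open how an amine or a carboxylic acid on the same saturated ring carbon, or a chain longer than the single methyl of compound 3, would read in this assay. They also leave open the separate contributions of the parts of the exchange: (morpholin-4-yl)carbonyl held directly on the ring carbon would isolate the methyl, and (azetidin-1-yl)carbonyl would isolate the hydroxyl.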